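Shortening a Propyl Chain to Methyl

This account rests on a few compounds, and the source may have more. Where it says the series, first, only, none or still open, it means among the compounds named here.

Compound 1 `CCCn1c(-c2ccc(Cl)cc2)nn(C)c1=S` gives > 12.5 mg/kg (a limit)
Compound 2 `Cn1nc(-c2cccc(C(F)(F)F)c2)n(C)c1=S` gives > 50 mg/kg (a limit)

In a functional assay on the whole organism with Mus musculus as the target (a lower number here means that less compound is needed, a higher number that more compound is needed for the effect), compound 1 is recorded only as the limit > 12.5 mg/kg and has no exact number. Compound 2 is likewise recorded only as a limit. Compound 3 `Cn1nc(-c2ccc(Cl)cc2)n(C)c1=S` shortens the propyl chain of compound 1 to methyl (hydrogen in place of ethyl on a saturated chain carbon bound to an aromatic nitrogen), with hydrogen in place of ethyl on a saturated chain carbon bound to an aromatic nitrogen. Among the measured compounds shown here, no measured pair shows this change, so no step beyond the usual scatter is expected in this assay and its direction stays open. The expected step is a step that the limit leaves unreadable from compound 1 to compound 3. The estimate for compound 3 is 15 mg/kg, within an expected range of 5 mg/kg to 50 mg/kg.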

Compound 3, dose for half-maximal effect: 1.34 mg/kg
For compound 3 the middle estimate is 11-fold (1.05 log units) above the measured one; measured number below the stated range.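

Shortening the propyl chain to methyl gives, in this assay, an at least 9.3-fold lower number from compound 1 to compound 3 (0.96 log units; beyond the scatter). Among the compounds shown here, this is the first exact number, and it shows that this chain matters: with methyl in place of propyl, the effect appears at a clearly lower dose. From the compounds shown here alone, compound 1 is recorded only as the limit > 12.5 mg/kg, so the full size of the step stays unknown.

With only propyl and methyl shown at this place, it remains open how an ethyl chain would behave. The reason for the step also remains open.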